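The compounds below may be only part of what the source reports. "The series", "measured", "known", "first", "only" and "open" are said of these compounds alone.

Working notes on the series. Two compounds have numbers in an assay on isolated protein for inhibition of sterol O-acyltransferase 1 (Mus musculus), tested at 0.1 uM; on this read-out lower numbers stand for less inhibition and higher numbers for more inhibition at the one concentration tested (going by the name of the read-out). Compound 1 `CCCCCCCCCCCCn1nnc(CCC(=O)Nc2c(C(C)C)cccc2C(C)C)n1` gives 17% in this assay. For the measured compounds named here, compound 2 `CCCCCCCCCCCCc1nnn(CC(=O)Nc2c(OC)cc(OC)cc2OC)n1` gives 61% in this assay, the higher of the two numbers, with compound 1 standing a gap below it that lies beyond the usual scatter; no step is recorded between these two, as they differ in more than one place.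

Compound 3 `CCCCCCCCCCCCc1nnn(C(C(=O)Nc2c(OC)cc(OC)cc2OC)c2ccccc2)n1` is the next member, not yet measured in this assay. Against compound 2 the change is phenyl in place of hydrogen on a saturated chain carbon bound to an aromatic nitrogen and a carbonyl carbon. Going by the values given here, no measured pair shows this change, so its size and direction are not known from the data. The step from compound 2 to compound 3 in this assay is expected to be small, on the order of a number 9 percentage points lower from compound 2 to compound 3 (within the scatter), and may fall within the scatter. Compound 3 is therefore estimated at 52% in this assay, with a range from 20% to 80%.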

Compound 3, a percentage reported as inhibition, at one concentration (the size of the read-out at that concentration, not a potency): 52%
The estimate for compound 3 equals the measured number at the digits printed; measured number inside the range.
By their numbers in this assay, from the lowest: compound 1; then compounds 3 and 2 (each within the scatter of the next).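

For the compounds shown here, on the saturated chain carbon bound to an aromatic nitrogen and a carbonyl carbon, the first reading in this assay for a change at this position is a number 9 percentage points lower from compound 2 to compound 3 (within the scatter). Phenyl in place of hydrogen, with its 6 heavy atoms and one six-membered aromatic ring, therefore shifts the number at this carbon by no more than the scatter allows, which the earlier compounds could not show. Nothing available bears on why this step stays so small.

With phenyl as the only group shown at this carbon, the outcome for a methyl, an amine or a carboxylic acid there remains open. Also open, as far as these compounds go, is whether a phenyl carrying a methoxy or a fluorine would read the same way in this assay.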